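A few compounds are considered here, and "the series" means these few. Any claim that something is new, unique, unknown or untested is made for them only; others in the source may bear on it.

Two compounds built on one shared core were tested in an ADME assay on NIH3T3 cells (Mus musculus) for antiproliferative activity, read by sulforhodamine B assay, with a stated time of 48 h; on this read-out lower numbers stand for stronger inhibition and higher numbers for weaker inhibition. Compound 1, `CC(C)(C)OC(=O)NCCC[C@@H]1N=C2C[C@@H]3C[C@@H](C3(C)C)[C@]2(C)OC1=O`, gives only a limit of the assay there, > 1200000 nM. Compound 2, `CC(C)(C)OC(=O)NCCCC[C@H]1N=C2C[C@H]3C[C@H](C3(C)C)[C@@]2(C)OC1=O`, likewise reaches only a limit, > 1300000 nM. On the numbers shown, compound 2 therefore stands at the edge of what this assay can report, with no measured number of its own; the whole evidence consists of two limits, the limit of > 1200000 nM in this assay, at which 1 of the 2 values shown sits, and (the limit of > 1300000 nM in this assay, at which 1 of the 2 values shown sits), and nothing more. Compound 3, `CC(C)(C)OC(=O)NCCC[C@H]1N=C2C[C@H]3C[C@H](C3(C)C)[C@@]2(C)OC1=O`, has not yet been measured. It differs from compound 2 in one place: (tert-butoxycarbonyl)amino in place of ((tert-butoxycarbonyl)amino)methyl on a saturated chain carbon, three bonds along the chain from a saturated ring carbon. Going by the values given here, no measured step between compounds of this set exists to tell how such a change plays out, so no movement is expected beyond the scatter, in either direction. In this assay compound 3 is expected to come out at about 1300000 nM, between 400000 nM and 4000000 nM, most probably again as a limit. The step expected from compound 2 to compound 3 is a number no higher from compound 2 to compound 3 (the limit leaves the size open).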

Compound 3, half-maximal inhibitory concentration: > 1500000 nM
Compound 3: no number, only a limit; the forecaster's own chance of this, stated with the estimate: 85%; middle value at least 1.1-fold (0.06 log units) away from the limit.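

Compound 3 also gives only a limit in this assay, so neither the step from compound 2 to compound 3 nor the step from compound 1 to compound 3 can be read. The compounds shown leave open what concentration any of the three needs for half-maximal inhibition, and whether swapping ((tert-butoxycarbonyl)amino)methyl for (tert-butoxycarbonyl)amino or inverting all stereocentres changes it.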